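Chalcone chloroacetamides: extending the chloroacetamide arm of compound 2

The source may report more compounds than this note shows. Statements on the series, on what has been measured and on what is new or still open speak of the compounds shown alone.

Measured so far in a functional assay on MCF7 cells (Homo sapiens) for cytotoxicity, read by MTT assay, with a stated time of 72 h; a lower number here means a stronger inhibitor, a higher number a weaker inhibitor:
compound 1 `O=C(CCl)Nc1ccc(C(=O)/C=C/c2ccccc2)cc1` gives 2480 nM
compound 2 `O=C(CCl)Nc1ccc(C(=O)/C=C/c2ccc([N+](=O)[O-])cc2)cc1` gives 3910 nM
compound 3 `Cc1ccc(/C=C/C(=O)c2ccc(NC(=O)CCl)cc2)cc1` gives 9180 nM

Compound 2 stands second highest of the three numbers. Its nearest neighbour is compound 1: the step of a 1.6-fold higher number from compound 1 to compound 2 (0.20 log units; within the scatter) is within the scatter, so the two are not ordered. The step of a 2.3-fold higher number from compound 2 to compound 3 (0.37 log units; beyond the scatter) is beyond the scatter, modest in size, and the step of a 3.7-fold higher number from compound 1 to compound 3 (0.57 log units; beyond the scatter) is the largest among the measured compounds.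

Compound 4 `O=C(CSC(=S)N[C@H]1CCOC1=O)Nc1ccc(C(=O)/C=C/c2ccc([N+](=O)[O-])cc2)cc1` keeps the shared core of compound 2 and differs from it in one place: a group of 10 heavy atoms (5 carbon, 1 nitrogen, 2 oxygen, 2 sulfur; one five-membered non-aromatic ring with 1 hetero atom) in place of one chlorine atom, on a saturated chain carbon bound to a carbonyl carbon. For the measured compounds named here, none of the measured steps touches this part of the molecule; all three concern substituents on an aromatic carbon. Going by the values given here, there is therefore no measured step that bears directly on the change from compound 2 to compound 4, and the expectation rests on the value of compound 2 alone, with a wide range.

Given that, compound 4 is expected to give an estimate of 4000 nM in this assay, with a range of 1000 nM to 16000 nM. The step of a 1.0-fold higher number from compound 2 to compound 4 (0.01 log units; within the scatter) is thus expected to be no larger than the scatter, in either direction, until the measurement is in hand.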

Compound 4, half-maximal inhibitory concentration: 2670 nM
Beside the measured number, compound 4's estimate is 1.5-fold (0.18 log units) above it; the measured number falls inside the stated range.
By their numbers in this assay, from the lowest: compounds 1, 4 and 2 (each within the scatter of the next); then compound 3.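

For the compounds shown here, this is the only step at the saturated chain carbon bound to a carbonyl carbon. In this assay it is a 1.5-fold lower number from compound 2 to compound 4 (0.17 log units; within the scatter), so the two compounds are not ordered, even though a single chlorine atom gives way to a group of 10 heavy atoms with one five-membered non-aromatic ring and 1 defined stereocentre. For this pair, then, a number of this size does not depend on the chlorine atom being present, and the position accepts a much larger group without a step beyond the scatter; no measured evidence accounts for this result.

The compounds shown do not tell whether the same replacement would hold on the core of compound 1 or the core of compound 3, where the substituent on the aromatic carbon differs. They also leave open which part of the entering group matters, and how a simple amine, a plain thioether, a longer alkyl chain or the opposite configuration at the stereocentre would read at this carbon.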